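Amine replacement on the core of compound 1

The source may hold more compounds than are shown below. What is called first, only, known or untested is meant among the compounds shown, and "the series" means these compounds.

Measured so far:
compound 1 `CCCN(CC1CC1)c1nc(CC)c(-c2ccc(Cl)cc2Cl)nc1CC`: 19.2 nM
compound 2 `CCc1nc(NC(CC)CC)c(Cl)nc1-c1ccc(Cl)cc1Cl`: 71 nM

Both numbers come from an assay on IMR-32 cells for displacement of a labelled ligand from corticotropin-releasing factor receptor 1 (Homo sapiens), read by scintillation counting, with a stated time of 2 h; a higher number here means a weaker inhibitor, a lower number a stronger inhibitor. Compound 1 stands at the lowest of the two numbers; compound 2 sits at a higher number, and that gap is beyond the usual scatter. Among the measured compounds shown here, the two measured compounds differ in more than one place, so no single-change step between them is available, and their values are taken only as they stand.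

Compound 3 `CCc1nc(-c2ccc(Cl)cc2Cl)c(CC)nc1NC(COC)COC` is the next compound to be measured. It differs from compound 1 in one place: (2-methoxy-1-(methoxymethyl)ethyl)amino in place of (cyclopropylmethyl)(propyl)amino on an aromatic carbon. The rest of the structure is unchanged.

For the measured compounds named here, no measured step bears directly on this change, so its size in this assay is open. The working expectation is a small shift toward a higher number, possibly within the scatter. Compound 3 is expected to give about 30 nM (range 8 nM to 120 nM). The expected step is a 1.6-fold higher number from compound 1 to compound 3 (0.19 log units; within the scatter).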

Compound 3, inhibition constant: 224 nM
Compound 3: middle estimate off by 7.5-fold (0.87 log units), on the low side; measured number outside the range, above it.
By their numbers in this assay, from the lowest: compound 1; then compound 2; then compound 3.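

In this assay, the aromatic carbon para to the 2,4-dichlorophenyl group proves sensitive to the choice of amine: with the heavy-atom count unchanged, (2-methoxy-1-(methoxymethyl)ethyl)amino in place of (cyclopropylmethyl)(propyl)amino gives a 12-fold higher number from compound 1 to compound 3 (1.07 log units; beyond the scatter). Among the compounds shown here, this is the first single-place step, and it lies beyond the scatter. The change alters the ring, hydrogen-bond donor and hydrogen-bond acceptor counts together, and nothing measured here shows which of these differences accounts for the step.

Still open, as far as these compounds go, is how the amine hydrogen and the two methoxy groups each contribute to the step. On the core of compound 1, a bis(2-methoxyethyl)amino group would keep the ether oxygens without the amine hydrogen, while a dipropylamino group would test the cyclopropylmethyl group alone.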